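Cytotoxicity of compound 4 estimated from its close relatives

The compounds below may be only part of what the source reports. "The series", "measured", "known", "first", "only" and "open" are said of these compounds alone.

The series shares one core. Compound 1 `Cc1cc(-c2ccco2)c2ncc(CSCCc3ccccc3)n2c1` gives 100 ug/mL in an ADME assay on HEL cells (Homo sapiens) for cytotoxicity, with a stated time of 3 days; a lower number here means that less compound is tolerated, a higher number that more compound is tolerated. Compound 2 `Cc1cc(N2CCCC2)c2ncc(CSCCc3ccccc3)n2c1` reaches only a limit in this assay, namely > 100 ug/mL. The step of a number no lower from compound 1 to compound 2 (the limit leaves the size open) therefore cannot be sized, in line with the limit of > 100 ug/mL in this assay, at which 1 of the 3 values shown sits. For compound 3 `Cc1cc(N2CCN(C)CC2)c2ncc(CSCCc3ccccc3)n2c1` the outcome in this assay is "not determined" (no result reported), so compound 3 stands without a number. Compound 4 `Cc1cc(N2CCCC2=O)c2ncc(CSCCc3ccccc3)n2c1` differs from compound 3 by 2-oxopyrrolidin-1-yl in place of 4-methylpiperazin-1-yl on an aromatic carbon. For the measured compounds named here, no measured step bears directly on this change; the only step known, from a different pair, is not readable. The expected step in this assay is therefore none beyond the scatter, and compound 4 is estimated at 100 ug/mL, within 50 ug/mL to 200 ug/mL.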

Compound 4, minimum cytotoxic concentration: 20 ug/mL
Beside the measured number, compound 4's estimate is 5.0-fold (0.70 log units) above it, and the stated range ends above it.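

In this assay, the group on this aromatic carbon now shifts the number beyond the scatter, with a 5.0-fold lower number from compound 1 to compound 4 (0.70 log units; beyond the scatter) when 2-oxopyrrolidin-1-yl replaces furan-2-yl. The carbonyl is the only difference between pyrrolidin-1-yl and 2-oxopyrrolidin-1-yl, and adding it brings an at least 5.0-fold lower number from compound 2 to compound 4 (0.69 log units; beyond the scatter). Compound 2 gives only a limit, so this step has a lower bound and no exact size: the limit of > 100 ug/mL in this assay, at which 1 of the 4 values shown sits.

The steps from compound 1 to compound 2 and from compound 3 to compound 4 cannot be read. From the compounds shown here alone, it remains open whether an open-chain acetamido group or a six-membered 2-oxopiperidin-1-yl ring at this carbon would also lower the number.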